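Series notes: amide tail change on the shared core

The source may hold more compounds than are shown below. What is called first, only, known or untested is meant among the compounds shown, and "the series" means these compounds.

Compound 1 `Nc1cccc2c(-c3cccc(NC(=O)c4ccc(Cl)c(C(F)(F)F)c4)c3)ccnc12` and compound 2 `CC(=O)Nc1cccc2c(-c3cccc(NC(=O)c4ccc(Cl)c(C(F)(F)F)c4)c3)ccnc12` share a core and differ only at the ring nitrogen substituent, acetyl in place of hydrogen. In a functional assay on A375P cells (Homo sapiens) for antiproliferative activity, read by MTT assay, with a stated time of 48 h (a higher number here means a weaker inhibitor, a lower number a stronger inhibitor), compound 1 gives 1400 nM, and compound 2 gives 2400 nM; the step of a 1.7-fold higher number from compound 1 to compound 2 (0.23 log units; within the scatter) lies within the scatter, so the two cannot be ordered. Compound 2 nonetheless holds the highest of the two numbers shown, with compound 1 nearest.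

Compound 3 `CC(=O)Nc1cccc2c(-c3cccc(NC(=O)c4nccs4)c3)ccnc12` keeps the acetyl of compound 2 and alters the amide tail: 1,3-thiazol-2-yl in place of 4-chloro-3-(trifluoromethyl)phenyl on a carbonyl carbon. For the measured compounds named here, the single measured step, from compound 1 to compound 2, concerns the ring nitrogen and not the carbonyl substituent, so no measured step bears on this change. The data give no guide to the size or direction of the effect of exchanging the tail; the expectation below is therefore uncertain and wide.

For compound 3 the expected step in this assay is a 3.3-fold higher number from compound 2 to compound 3 (0.52 log units; beyond the scatter), toward a higher number. Compound 3 is estimated at 8000 nM, with a range from 2000 nM to 40000 nM.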

Compound 3, half-maximal inhibitory concentration: > 20000 nM
Compound 3 was reported as a limit; the forecaster's own chance of this, stated with the estimate: 15%; middle value at least 2.5-fold (0.39 log units) away from the limit.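

In this assay, for the compounds shown here, the carbonyl carbon emerges as a position that responds: 1,3-thiazol-2-yl in place of 4-chloro-3-(trifluoromethyl)phenyl gives an at least 8.3-fold higher number from compound 2 to compound 3 (0.92 log units; beyond the scatter), whereas the only earlier step, on the ring nitrogen, was a 1.7-fold higher number from compound 1 to compound 2 (0.23 log units; within the scatter). Compound 3 gives > 20000 nM, which is a limit of the assay and not a number: the limit of > 20000 nM in this assay, at which 1 of the 3 values shown sits. The change replaces a six-membered aromatic ring of carbon only, carrying chlorine and trifluoromethyl, with a five-membered aromatic ring with 2 hetero atoms and 2 hydrogen-bond acceptors, and this single step cannot assign the loss to any one of these differences.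

As far as these compounds go, it remains open which part of 4-chloro-3-(trifluoromethyl)phenyl matters; a plain phenyl, or a phenyl carrying only chlorine or only trifluoromethyl, on the carbonyl carbon would separate these parts. Also open is whether the substituent on the ring nitrogen matters with the 1,3-thiazol-2-yl tail, as the compounds shown pair that tail only with the acetyl.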